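A few compounds are considered here, and "the series" means these few. Any claim that something is new, unique, unknown or untested is made for them only; others in the source may bear on it.

Of the compounds shown here, three built on one shared core have been measured in an assay on membranes from brain for displacement of a labelled ligand from Neuronal acetylcholine receptor; alpha4/beta2 (Rattus norvegicus), with a stated time of 3 h; a higher number here means a weaker inhibitor, a lower number a stronger inhibitor. Compound 1 `CCCc1ccc(/C=C2\CCCN=C2c2cccnc2)cc1` gives 890 nM. Compound 2 `COc1ccc(/C=C2\CCCN=C2c2cccnc2)c(OC(C)=O)c1` gives 770 nM in this assay, and compound 3 `Cc1cc(O)cc(C)c1/C=C1\CCCN=C1c1cccnc1` gives 670 nM. Compound 1 carries the highest of the three numbers, yet its gap to compound 2 and its gap to compound 3 both lie within the usual scatter of this kind of measurement, so the three compounds stand at one level and none of them can be called weaker or stronger than the others.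

Compound 4 `Clc1ccc(/C=C2\CCCN=C2c2cccnc2)cc1` has not yet been measured. It differs from compound 1 in a single place: chloro in place of propyl on an aromatic carbon. Each of the three measured variations at that aromatic ring leaves the value within the scatter of the others, and nothing among them sets a chloro apart from a propyl. The step from compound 1 to compound 4 is therefore expected to be small, in no direction that would exceed the scatter, estimated as a 1.2-fold lower number from compound 1 to compound 4 (0.07 log units; within the scatter). Compound 4 is expected to give about 750 nM in this assay, with a likely range from 280 nM to 2000 nM.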

Compound 4, inhibition constant: 970 nM
The estimate for compound 4 lay 1.3-fold (0.11 log units) below the measured number, and the stated range covers the measured number.
By their numbers in this assay, from the lowest: compounds 3, 2, 1 and 4 (each within the scatter of the next).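

Among the compounds shown here, the exchange of propyl for chloro on this aromatic carbon, para to a large group, gives a 1.1-fold higher number from compound 1 to compound 4 (0.04 log units; within the scatter) in this assay, the first comparison in this set that isolates a single place. At this position, then, the read-out stays at one level when a chain of 3 heavy atoms gives way to a single chlorine, and neither group carries a hydrogen-bond donor or acceptor. No measurement at hand explains why these two groups read alike.

Whether this position can move the value beyond the scatter at all remains open, as the only single-place step shown stays within it. From the compounds shown here alone, an amine, a carboxylic acid or a longer chain such as hexyl at this carbon could answer that, and their effect here is unknown.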